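A few compounds are considered here, and "the series" means these few. Any claim that something is new, unique, unknown or untested is made for them only; others in the source may bear on it.

Among the compounds with values here, compound 3 `COC(=O)c1ccc(NCc2cncn2Cc2ccc(Cl)cc2)cc1-c1ccccc1` is the one member of this set that returns a number in a toxicity assay on NIH3T3 cells (Mus musculus) for cytotoxicity, read by resazurin assay (on this read-out lower numbers stand for an effect already at smaller amounts and higher numbers for an effect only at larger amounts of compound), where compound 3 gives 25000 nM. For compound 1 `COC(=O)c1ccc(NCc2cncn2Cc2ccccc2C(C)(C)C)cc1-c1ccccc1` the entry in this assay is "not determined" (no result reported). Compound 2 `COC(=O)c1ccc(NCc2cncn2Cc2cccc(C#N)c2)cc1-c1ccccc1` reaches only a limit in this assay, reported as > 10000 nM. Within the data shown here, the single step with two measured ends, a step that the limit leaves unreadable from compound 2 to compound 3, cannot be sized because the limit of > 10000 nM in this assay, at which 1 of the 3 values shown sits, caps one end of it, so no measured step here tells how a change on the benzyl group moves the read-out.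

Compound 4 `COC(=O)c1ccc(NCc2cncn2Cc2cccc([N+](=O)[O-])c2)cc1-c1ccccc1` differs from compound 3 by 3-nitrophenyl in place of 4-chlorophenyl on a saturated chain carbon bound to an aromatic nitrogen. With no readable step to lean on, and with compound 3 sitting at 25000 nM near the top of the range that this assay resolves, the expectation is a step of a 1.1-fold lower number from compound 3 to compound 4 (0.06 log units; within the scatter), none beyond the scatter. Compound 4 is therefore estimated at 22000 nM in this assay, within a range from 8000 nM to 60000 nM, with a real chance that only a limit is returned.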

Compound 4, half-maximal effective concentration: > 10000 nM
Compound 4: no number, only a limit; the forecaster's own chance of this, stated with the estimate: 40%; the middle value does not contradict the limit.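

In this assay compound 4 returns only a limit, so its steps from compound 2 and compound 3 cannot be read, because the limit caps them: the limit of > 10000 nM in this assay, at which 2 of the 4 values shown sit.

The compounds shown leave open how far any change on the benzyl group moves the read-out in this assay.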